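This account rests on a few compounds, and the source may have more. Where it says the series, first, only, none or still open, it means among the compounds named here.

Measured compounds and their values in a functional assay on A2780 cells (Homo sapiens) for inhibition, read by MTT assay, with a stated time of 72 h; on this read-out higher numbers stand for weaker inhibition of growth and lower numbers for stronger inhibition of growth:
- compound 1, `CC(C)(C)c1ccc(CNCCCNS(=O)(=O)c2cc(C(F)(F)F)cc(C(F)(F)F)c2)cc1`: 2900 nM
- compound 2, `O=S(=O)(NCCCCNCc1ccc(Br)cc1)c1cc(C(F)(F)F)cc(C(F)(F)F)c1`: 2100 nM
- compound 3, `O=S(=O)(NCCCNCc1ccc(C(F)(F)F)cc1)c1cc(C(F)(F)F)cc(C(F)(F)F)c1`: 2800 nM

Among these, compound 3 gives the second highest number in this assay. Within the data shown here, its nearest neighbour is compound 1, which lies within the scatter of it, and the furthest is compound 2, which also lies within the scatter; no step between compound 2 and compound 3 is given, so only their two values can be compared, and they do not separate.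

Compound 4, `O=S(=O)(NCCCNCc1ccccc1)c1cc(C(F)(F)F)cc(C(F)(F)F)c1`, differs from compound 3 by one change: hydrogen in place of trifluoromethyl on an aromatic carbon. Among the measured compounds shown here, the one measured step that bears on this place is a 1.0-fold lower number from compound 1 to compound 3 (0.02 log units; within the scatter), in which one large group replaced another on the same aromatic carbon without moving the number beyond the scatter. For the measured compounds named here, removing the group altogether is a different change, and no measured pair shows it directly, but the only evidence at that position points to this assay being little sensitive to what sits there.

Compound 4 is therefore expected to land close to compound 3, with a 1.1-fold higher number from compound 3 to compound 4 (0.03 log units; within the scatter) as the estimated step, so that compound 4 is estimated at 3000 nM, within a range of 1500 nM to 6500 nM.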

Compound 4, concentration for 50% growth inhibition: 4900 nM
Beside the measured number, compound 4's estimate is 1.6-fold (0.21 log units) below it; the measured number falls inside the stated range.
By their numbers in this assay, from the lowest: compounds 2, 3, 1 and 4 (each within the scatter of the next, the first and the last beyond it).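

In this assay, hydrogen in place of trifluoromethyl gives a 1.8-fold higher number from compound 3 to compound 4 (0.24 log units; within the scatter), and hydrogen in place of tert-butyl gives a 1.7-fold higher number from compound 1 to compound 4 (0.23 log units; within the scatter), so this aromatic carbon has now been read with nothing on it as well as with two large groups. Neither group separates from the plain phenyl, which extends the earlier finding from an exchange of one group for another to the loss of the group altogether, and across these three compounds the position shows no effect that can be told from the scatter. Among these compounds, the only step here that goes beyond the scatter is a 2.3-fold higher number from compound 2 to compound 4 (0.37 log units; beyond the scatter), which is modest and cannot be assigned to this position alone, since compound 2 differs from compound 4 in its chain as well as in the bromine on its ring.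

Nothing available here accounts for these numbers. The compounds shown leave open whether a hydroxyl, a methoxy or a carboxylic acid on this aromatic carbon would move the number beyond the scatter, and whether the bromine or the longer chain of compound 2 is what separates it from compound 4.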